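The source may hold more compounds than are shown below. What is called first, only, known or untested is meant among the compounds shown, and "the series" means these compounds.

In an ADME assay on the whole organism (strain CD-1) for pharmacokinetics, with Mus musculus as the target, at a dose of 3 mg/kg by the intravenous route (on this read-out lower numbers stand for lower exposure and higher numbers for higher exposure at the dose given), compound 1 `C[C@@H](CCCOc1ccccc1CN(C)C(=O)c1ccc(-c2ccco2)cc1)CC(=O)O` gives 30800 ng.h/mL and compound 2 `CN(Cc1ccccc1OCCC[C@@H]1C[C@@H]1C(=O)O)C(=O)c1ccc(-c2ccco2)cc1` gives 30100 ng.h/mL. For the measured compounds named here, these two numbers lie within the usual scatter of each other, so compound 2 cannot be separated from the only other compound measured so far. The next structure is compound 3 `CC(CCOc1ccccc1CN(C)C(=O)c1ccc(-c2ccco2)cc1)CCC(=O)O`, and the change is 3-carboxy-1-methylpropyl in place of (2-carboxycyclopropyl)methyl on a saturated chain carbon, two bonds along the chain from an oxygen on an aromatic ring. Put simply, 3-carboxy-1-methylpropyl takes the place of (2-carboxycyclopropyl)methyl, on a saturated chain carbon, two bonds along the chain from an oxygen on an aromatic ring. The three-membered ring is gone, and the heavy-atom count of the group stays the same. Going by the values given here, one measured step bears on this: a 1.0-fold lower number from compound 1 to compound 2 (0.01 log units; within the scatter), which also exchanges a group with no ring and a group holding the 2-carboxycyclopropyl unit, and which stays within the scatter. Among the compounds with values here, it is only a single step, and the open chain of compound 3 is not the chain of compound 1, so the expectation is loose. No step beyond the scatter is expected in this assay, and the estimated change is a 1.1-fold lower number from compound 2 to compound 3 (0.03 log units; within the scatter). For compound 3 the expected value is 28000 ng.h/mL, with an estimated range of 12000 ng.h/mL to 60000 ng.h/mL.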

Compound 3, area under the concentration-time curve: 11800 ng.h/mL
For compound 3 the middle estimate is 2.4-fold (0.38 log units) above the measured one; the measured number lies below the stated range.
By their numbers in this assay, from the lowest: compound 3; then compounds 2 and 1 (each within the scatter of the next).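

In this assay, this position proves sensitive to the change: placing 3-carboxy-1-methylpropyl where (2-carboxycyclopropyl)methyl stood, on a saturated chain carbon, two bonds along the chain from an oxygen on an aromatic ring, gives a 2.6-fold lower number from compound 2 to compound 3 (0.41 log units; beyond the scatter), even though the heavy-atom count of the group stays the same. Compound 1 also has no ring in this chain, yet 3-carboxy-1-methylpropyl in place of 2-(carboxymethyl)propyl gives a 2.6-fold lower number from compound 1 to compound 3 (0.42 log units; beyond the scatter), so the absence of the three-membered ring does not by itself go with the lower number, and the earlier pair, whose step stayed within the scatter, gave no sign of this sensitivity. Nothing at hand explains why compound 3 parts from the other two compounds.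

With so few compounds, the methyl branch and the length of the chain leading to the carboxylic acid cannot be separated as the feature that matters. On these data alone, it remains open whether an unbranched chain would give a number like that of compound 3 or those of compounds 1 and 2, and what a tetrazole in place of the carboxylic acid would give in this assay.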